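Sulfonyl aryl exchange on the lactam sulfonamide series

The compounds below may be only part of what the source reports. "The series", "measured", "known", "first", "only" and "open" are said of these compounds alone.

Working notes. All numbers come from an assay on isolated protein for inhibition of coagulation factor X (Oryctolagus cuniculus), tested at 0.1 uM; on this read-out lower numbers stand for less inhibition and higher numbers for more inhibition at the one concentration tested (going by the name of the read-out). Compound 1 `O=C1[C@@H](NS(=O)(=O)c2cc3ccc(Cl)cc3s2)CCN1Cc1cc2cc[nH]cc-2n1` gives 50%. Compound 3 `O=C1[C@@H](NS(=O)(=O)c2cc3ccc(Cl)cc3s2)CCN1CCNc1ccncc1` gives 57%, and compound 2 `O=C1[C@@H](NS(=O)(=O)c2ccc(-c3ccc(Cl)s3)s2)CCN1CCNc1ccncc1` gives 77%. Compound 1 thus holds the lowest of the three numbers; compound 3 lies within the scatter of it, whereas compound 2 lies beyond the scatter above it.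

Among the measured compounds shown here, the only measured step, a number 7 percentage points higher from compound 1 to compound 3 (within the scatter), concerns the group on the saturated chain carbon bound to the amide-type nitrogen in the ring and leaves the read-out essentially unchanged.

Compound 4 `O=C1[C@@H](NS(=O)(=O)c2cc3ncccc3s2)CCN1Cc1cc2cc[nH]cc-2n1` differs from compound 1 at the sulfonyl sulfur: a group of 9 heavy atoms (7 carbon, 1 nitrogen, 1 sulfur; one five-membered aromatic ring with 1 hetero atom, one six-membered aromatic ring with 1 hetero atom) in place of a group of 10 heavy atoms (8 carbon, 1 sulfur, 1 chlorine; one five-membered aromatic ring with 1 hetero atom, one six-membered aromatic ring of carbon only), on a sulfonyl sulfur. For the measured compounds named here, no measured compound varies this side of the molecule, so no step in hand bears directly on the change; the one step available sits elsewhere and was small. The expectation therefore rests on the structural change alone, with the chlorine-bearing group giving way to a ring that carries a nitrogen in place of the chlorine. A drop beyond the scatter is expected, the estimated step being a number 20 percentage points lower from compound 1 to compound 4 (beyond the scatter). Compound 4 is estimated at 30%, within a range from 5% to 60%.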

Compound 4, a percentage reported as inhibition, at one concentration (the size of the read-out at that concentration, not a potency): 52%
The estimate for compound 4 lay 22 percentage points below the measured number; the measured number falls inside the stated range.
By their numbers in this assay, from the lowest: compounds 1, 4 and 3 (each within the scatter of the next); then compound 2.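

The first step measured on the sulfonyl sulfur in this assay is a number 2 percentage points higher from compound 1 to compound 4 (within the scatter) with 6-chloro-1-benzothiophen-2-yl leaving and a group entering that carries a ring nitrogen and no chlorine. With the substituent of compound 1 on the amide-type nitrogen in the ring, the chlorine-bearing group is therefore not needed to keep the inhibition read at this one concentration, and this pair gives no sign that the sulfonyl aryl exchange costs inhibition. No measurement in hand accounts for the two groups reading alike.

Open, going by these compounds, is whether the same exchange reads alike with the substituent of compound 3 on that nitrogen, the more so as a different group on the sulfonyl sulfur gives compound 3 57% and compound 2 77% in this assay on the same side chain. Also open, on these data alone, is what a bromine or a methoxy group would do in the place of the chlorine on the benzothiophene, and whether a ring nitrogen elsewhere in the bicyclic group would read the same.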